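Adding a Chlorine to the Anilino Ring

A few compounds are considered here, and "the series" means these few. Any claim that something is new, unique, unknown or untested is made for them only; others in the source may bear on it.

Going by the values given here, compound 2 (`O=C(Nc1sc2c(c1C(=O)NNc1ccccc1)CCCCC2)NS(=O)(=O)c1ccccc1`) is the only compound here with a number rather than a limit in a functional assay on cells (Cancer cell lines, Homo sapiens) for inhibition, with a stated time of 48 h (a higher number here means a weaker inhibitor of growth, a lower number a stronger inhibitor of growth), where compound 2 gives 30900 nM. Compound 1 (`NNC(=O)c1c(NC(=O)NS(=O)(=O)c2ccccc2)sc2c1CCCCC2`) differs from compound 2 by one change. In this assay compound 1 gives > 100000 nM, which is a limit of the assay and not a number. The step of an at least 3.2-fold lower number from compound 1 to compound 2 (0.51 log units; beyond the scatter) shows that the phenyl in place of hydrogen on an amine nitrogen strengthened inhibition at least modestly. Compound 3 (`O=C(Nc1sc2c(c1C(=O)NNc1ccc(Cl)cc1)CCCCC2)NS(=O)(=O)c1ccccc1`) carries a further change: chloro in place of hydrogen on an aromatic carbon. Among the compounds with values here, no measured step touches a substituent on that phenyl ring, so the one known step gives only indirect guidance. The estimate for compound 3 in this assay is 25000 nM, with a range from 8000 nM to 100000 nM. Accordingly the expected step of a 1.2-fold lower number from compound 2 to compound 3 (0.09 log units; within the scatter) is one that stays within the scatter.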

Compound 3, concentration for 50% growth inhibition: 12000 nM
For compound 3 the middle estimate is 2.1-fold (0.32 log units) above the measured one, and the stated range covers the measured number.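

Going by these compounds alone, the anilino ring had not been varied by any earlier step, and chloro, para to a large group, gives the first reading of this position: in this assay there is a 2.6-fold lower number from compound 2 to compound 3 (0.41 log units; beyond the scatter), so one added chlorine on this ring moves growth inhibition modestly but beyond the scatter. Measured against the simple hydrazide end of compound 1, the full change of hydrogen on the amine nitrogen to 4-chlorophenyl gives an at least 8.3-fold lower number from compound 1 to compound 3 (0.92 log units; beyond the scatter). That step has only a lower bound, as compound 1 stands at a limit of the assay and not at a number: the limit of > 100000 nM in this assay, at which 1 of the 3 values shown sits.

As far as these compounds go, a single chloro cannot show whether this gain is specific to chlorine, so fluoro, methyl or methoxy at that place remain open. Chloro elsewhere on the ring and changes to the shared core also remain open.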